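This account rests on a few compounds, and the source may have more. Where it says the series, first, only, none or still open, it means among the compounds named here.

Measured compounds:
compound 1, `N#Cc1ccc(Nc2nccc(SC3CCCCC3)n2)cc1`, > 402000 nM
compound 2, `Cc1cc(NC2CCCC2)nc(Nc2ccc(C#N)cc2)n1`, 310 nM

Among the compounds with values here, in an ADME assay on MT4 cells (Homo sapiens) for cytotoxicity, read by MTT assay (on this read-out lower numbers stand for higher toxicity in this test and higher numbers for lower toxicity in this test), compound 2 gives 310 nM, the only real number recorded here. For compound 1 the same assay reports only a limit, > 402000 nM. That is the limit of > 402000 nM in this assay, at which 1 of the 2 values shown sits, and it is the edge of the assay rather than a measured number. Compound 2 therefore stands as the single reference point with a definite value.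

Compound 3, `N#Cc1ccc(Nc2nccc(NC3CCCC3)n2)cc1`, has not yet been tested in this assay. It differs from compound 2 by hydrogen in place of methyl on an aromatic carbon. Within the data shown here, no pair of measured compounds shows this change, so its size cannot be read from the data. Compound 1, which also lacks the methyl, registers only the limit > 402000 nM. On that ground the change is expected to move toward lower toxicity, with a step of an 8.1-fold higher number from compound 2 to compound 3 (0.91 log units; beyond the scatter), though the amount is uncertain. Compound 3 is accordingly estimated at 2500 nM, within a range from 300 nM to 30000 nM.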

Compound 3, half-maximal cytotoxic concentration: 9130 nM
Compound 3: middle estimate off by 3.7-fold (0.56 log units), on the low side; low and high end bracket the measured number.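

In this assay, within the data shown here, the first measured reading of this change is a 29-fold higher number from compound 2 to compound 3 (1.47 log units; beyond the scatter), so hydrogen in place of methyl on this aromatic carbon, next to the ring nitrogen, goes with much lower toxicity in this test. With cyclopentylamino in place of cyclohexylsulfanyl on an aromatic carbon, the record shows an at least 44-fold lower number from compound 1 to compound 3 (1.64 log units; beyond the scatter), so the absence of the methyl alone does not place a compound at the high end of the read-out. That second step gives only a minimum size, since the figure for compound 1 is a limit of the assay and not a number: the limit of > 402000 nM in this assay, at which 1 of the 3 values shown sits.

The compounds shown leave open whether the methyl step would keep its size with cyclohexylsulfanyl rather than cyclopentylamino on the ring. They also leave open whether an ethyl or methoxy group in the place of the methyl would read like methyl or like hydrogen, and how a cyclohexylamino group would compare with cyclopentylamino.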